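The source may hold more compounds than are shown below. What is called first, only, known or untested is meant among the compounds shown, and "the series" means these compounds.

In a functional assay on PC-3 cells (Homo sapiens) for antiproliferative activity, read by MTT assay, with a stated time of 24 h (on this read-out higher numbers stand for weaker inhibition and lower numbers for stronger inhibition), three compounds sharing a common core have been measured. Compound 1 `CCn1c(C(=O)NCCC(=O)OC)ccc1C(CC)(CC)c1ccc(OCS(=O)(=O)c2ccccc2)c(C)c1` gives 40400 nM. Compound 2 `CCN(CC)CCNC(=O)c1ccc(C(CC)(CC)c2ccc(OCS(=O)(=O)c3ccccc3)c(C)c2)n1CC` gives 7130 nM, and compound 3 `CCn1c(C(=O)N[C@H](CO)C(C)C)ccc1C(CC)(CC)c1ccc(OCS(=O)(=O)c2ccccc2)c(C)c1` gives 7300 nM. Compound 3 thus stands second highest of the three: its number and that of compound 2 lie within the usual scatter of each other, so the two cannot be told apart, while compound 1 sits clearly higher. The steps recorded so far are a 5.7-fold lower number from compound 1 to compound 2 (0.75 log units; beyond the scatter) and a 5.5-fold lower number from compound 1 to compound 3 (0.74 log units; beyond the scatter), whereas a 1.0-fold higher number from compound 2 to compound 3 (0.01 log units; within the scatter).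

Compound 4 `CCn1c(C(=O)N[C@H](C(=O)O)C(C)C)ccc1C(CC)(CC)c1ccc(OCS(=O)(=O)c2ccccc2)c(C)c1` is the next compound, and it differs from compound 3 in one place: carboxy in place of hydroxymethyl on a saturated chain carbon bound to an amide-type nitrogen and a saturated chain carbon. Among the measured compounds shown here, no measured step covers this exact change. The two steps beyond the scatter both replaced the whole group on the amide-type nitrogen, and the step within the scatter shows that two quite different groups in that position gave the same number. On this basis the step is expected to be small, not beyond the scatter, in either direction, and for compound 4 the estimated step is a 1.2-fold higher number from compound 3 to compound 4 (0.09 log units; within the scatter). Compound 4 is therefore expected to give 9000 nM, within a range from 3500 nM to 25000 nM.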

Compound 4, half-maximal inhibitory concentration: 3650 nM
For compound 4 the middle estimate is 2.5-fold (0.39 log units) above the measured one, within the range that was stated.
By their numbers in this assay, from the lowest: compounds 4, 2 and 3 (each within the scatter of the next); then compound 1.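

In this assay, carboxy in place of hydroxymethyl on the saturated chain carbon gives a 2.0-fold lower number from compound 3 to compound 4 (0.30 log units; within the scatter) and so, unlike the earlier swaps of the whole group on the amide-type nitrogen, this smaller change within that group leaves the two compounds indistinguishable. Among the compounds shown here, the 1-carboxy-2-methylpropyl group also cannot be told apart from 2-(diethylamino)ethyl, with a 2.0-fold lower number from compound 2 to compound 4 (0.29 log units; within the scatter) on that swap, while its replacement of 2-(methoxycarbonyl)ethyl gives an 11-fold lower number from compound 1 to compound 4 (1.04 log units; beyond the scatter) as the largest step so far, which leaves compound 1 as the weakest of the four and the only one set apart from the others. Nothing given here bears on the reason for these numbers.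

The compounds shown leave open whether the high number of compound 1 goes with its methoxycarbonyl group or with its unbranched chain: a 2-carboxyethyl group on the amide-type nitrogen, or methoxycarbonyl in place of carboxy in compound 4, would separate the two. Also open, going by these compounds, is what an amine or a primary amide would give on that same saturated chain carbon.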